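The source may report more compounds than this note shows. Statements on the series, on what has been measured and on what is new or still open speak of the compounds shown alone.

Among the measured compounds shown here, in a physicochemical assay for solubility (on this read-out lower numbers stand for lower solubility and higher numbers for higher solubility), compound 1 `O=C(Nc1ccccc1Cl)c1cc(Cl)ccc1O` gives 5 ug/mL, the lower of the only two true numbers so far. Compound 3 `O=C(Nc1c(Cl)cccc1Cl)c1cc(Cl)ccc1O` gives 21 ug/mL. Compound 2 `O=C(Nc1ccc(Cl)cc1Cl)c1cc(Cl)ccc1O` returns only a limit of the assay, < 1 ug/mL. Compound 4 `COc1ccc(Cl)c(NC(=O)c2cc(Cl)ccc2O)c1` is not yet measured, and its change is methoxy in place of hydrogen on an aromatic carbon. The closest guides are two steps that put chloro in place of hydrogen on an aromatic carbon, and they point opposite ways: an at least 5.0-fold lower number from compound 1 to compound 2 (0.69 log units; beyond the scatter), but a 4.2-fold higher number from compound 1 to compound 3 (0.62 log units; beyond the scatter). Neither step involves methoxy, so no step beyond the scatter is expected. The estimated step is a 1.7-fold lower number from compound 1 to compound 4 (0.22 log units; within the scatter). For compound 4 the expected value is 3 ug/mL, with an expected range from 1 ug/mL to 10 ug/mL.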

Compound 4, solubility: < 1 ug/mL
Compound 4: only a limit was reported (the forecaster's own chance of this, stated with the estimate: 20%); middle value at least 3.0-fold (0.47 log units) from the limit.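

In this assay, methoxy in place of hydrogen on an aromatic carbon, meta to a large group and para to a chloro group, gives an at least 5.0-fold lower number from compound 1 to compound 4 (0.69 log units; beyond the scatter). So a group other than chloro can also lower the number from compound 1, here at a ring position not substituted in compound 2 or compound 3. Compound 4 gives only a limit, so this step has no exact size: the limit of < 1 ug/mL in this assay, at which 2 of the 4 values shown sit.

The compounds shown do not separate the role of methoxy from that of this position. No chloro, amine or carboxylic acid stands at this carbon.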